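Swapping a Fluorinated Ring for tert-Butyl: Cytotoxicity Outlook

The compounds below may be only part of what the source reports. "The series", "measured", "known", "first", "only" and "open" are said of these compounds alone.

Compound 1, `C[C@H]1CC[C@H](C(=O)N(c2cc(C#CC3(C(F)(F)F)CCC3)sc2C(=O)O)[C@H]2CC[C@H](Oc3ccc(=O)[nH]n3)CC2)CC1`: > 20000 nM
Compound 2, `CC(C)(C)C#Cc1cc(N(CCO)C(=O)[C@H]2CC[C@H](C)CC2)c(C(=O)O)s1`: > 20000 nM

In an ADME assay on MT4 cells (Homo sapiens) for cytotoxicity, with a stated time of 5 days (on this read-out higher numbers stand for lower toxicity in this test and lower numbers for higher toxicity in this test), compound 1 gives > 20000 nM, which is a limit of the test rather than a number. Compound 2 likewise gives > 20000 nM, also a limit. Both values sit at the limit of > 20000 nM in this assay, at which 2 of the 2 values shown sit, so compound 1 stands at the edge of what the test reports, with nothing measured beyond it.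

Compound 3, `CC(C)(C)C#Cc1cc(N(C(=O)[C@H]2CC[C@H](C)CC2)[C@H]2CC[C@H](Oc3ccc(=O)[nH]n3)CC2)c(C(=O)O)s1`, is not yet measured. It differs from compound 1 by tert-butyl in place of 1-(trifluoromethyl)cyclobutyl on a triple-bonded carbon. For the measured compounds named here, no step between measured compounds is available for guidance. The step that the limit leaves unreadable from compound 1 to compound 3 is expected to stay within the usual scatter, in no particular direction. Compound 3 is therefore expected to give about 30000 nM, somewhere between 10000 nM and 100000 nM, most likely again reported only as a limit.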

Compound 3, half-maximal cytotoxic concentration: > 20000 nM
Compound 3: a limit, no number (the forecaster's own chance of this, stated with the estimate: 85%); the middle value is on the limit's open side.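

For the compounds shown here, compound 1 and compound 3 both stop at a limit of the test, so no step between them can be read: the limit of > 20000 nM in this assay, at which 3 of the 3 values shown sit.

On these data alone, whether tert-butyl in place of 1-(trifluoromethyl)cyclobutyl alters cytotoxicity at all, and how these compounds would rank, stays open.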